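Crown-ether esters and HeLa growth: from phenethyl to indolyl

The compounds below may be only part of what the source reports. "The series", "measured", "known", "first", "only" and "open" are said of these compounds alone.

Measured compounds:
compound 1 `O=C(CCCCCc1ccccc1)OCC1COCCOCCOCCOCCOCCO1` — 79000 nM
compound 2 `O=C(CCCCC1CCCCC1)OCC1COCCOCCOCCOCCO1` — > 100000 nM
compound 3 `O=C(OCC1COCCOCCOCCOCCOCCO1)c1cccc(-c2ccc(Br)cc2)c1` — 7800 nM

The three compounds share a crown-ether core carrying an ester side chain. In a functional assay on HeLa cells (Homo sapiens) for inhibition, read by sulforhodamine B assay, with a stated time of 48 h (on this read-out higher numbers stand for weaker inhibition of growth and lower numbers for stronger inhibition of growth), compound 1 gives 79000 nM. Compound 3 gives 7800 nM in this assay, so compound 1 holds the higher of the two numbers, with a gap to compound 3 that lies beyond the usual scatter. Compound 2 reports only a limit of this assay, > 100000 nM, and not a number; this is the case described as the limit of > 100000 nM in this assay, at which 1 of the 3 values shown sits.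

Compound 4 `O=C(CCCc1cc2ccccc2[nH]1)OCC1COCCOCCOCCOCCOCCO1` has not yet been measured. It differs from compound 1 in one place: 1H-indol-2-yl in place of phenethyl on a saturated chain carbon, three bonds along the chain from a carbonyl carbon. Within the data shown here, no measured pair shows a change of this kind, so the size of the step is uncertain; the account expects a modest move toward stronger growth inhibition, with the change from compound 1 to compound 4 estimated as a 2.0-fold lower number from compound 1 to compound 4 (0.30 log units; within the scatter). For compound 4 the estimated value in this assay is 40000 nM, within a range from 10000 nM to 150000 nM.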

Compound 4, concentration for 50% growth inhibition: > 100000 nM
Compound 4: no number, only a limit (the forecaster's own chance of this, stated with the estimate: 25%); middle value at least 2.5-fold (0.39 log units) from the limit.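

This position on the chain now has its first measured step: in this assay, 1H-indol-2-yl in place of phenethyl on a saturated chain carbon, three bonds along the chain from a carbonyl carbon, gives an at least 1.2-fold higher number from compound 1 to compound 4 (0.10 log units; that floor lies within the scatter). The added nitrogen, the hydrogen-bond donor and the second aromatic ring therefore bring no measurable gain in growth inhibition here, although the printed floor does not establish a real loss. Compound 4 gives only a limit of the assay and not a number, so the step cannot be sized beyond that floor: the limit of > 100000 nM in this assay, at which 2 of the 4 values shown sit.

The compounds shown leave open how far above this limit compound 4 lies. They also leave open whether a 1-methyl-1H-indol-2-yl group, an amine or a carboxylic acid at this position would shift the number.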